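Trifluoromethyl to Chloro: a Small Change Expected

This account rests on a few compounds, and the source may have more. Where it says the series, first, only, none or still open, it means among the compounds named here.

Within the data shown here, of the two numbers so far in an assay (strain Wistar) for displacement of a labelled ligand from adenosine receptor A1 (Rattus norvegicus), read by scintillation counting (a lower number here means a stronger inhibitor, a higher number a weaker inhibitor), compound 2 `O=C(Nc1nc(-c2ccccc2)nc2c1nnn2Cc1ccccc1)c1ccc(C(F)(F)F)cc1` has the higher, giving 123 nM, yet compound 1 `O=C(Nc1nc(-c2ccccc2)nc2c1nnn2Cc1ccccc1)c1cccc([N+](=O)[O-])c1`, which gives 77 nM, sits within the scatter of it, the step of a 1.6-fold higher number from compound 1 to compound 2 (0.20 log units; within the scatter) being small. Compound 3 `O=C(Nc1nc(-c2ccccc2)nc2c1nnn2Cc1ccccc1)c1ccc(Cl)cc1` differs from compound 2 by chloro in place of trifluoromethyl on an aromatic carbon. Among the measured compounds shown here, only that one measured step exists, and it swaps a whole different group, so it bears on this change only loosely; with nothing pointing either way, the expected step of a 1.1-fold lower number from compound 2 to compound 3 (0.05 log units; within the scatter) is none beyond the scatter. Compound 3 is therefore estimated at 110 nM, with a range from 40 nM to 300 nM.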

Compound 3, inhibition constant: 108 nM
Estimate against measurement, compound 3: 1.0-fold (0.01 log units) above, within the range that was stated.
By their numbers in this assay, from the lowest: compounds 1, 3 and 2 (each within the scatter of the next).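

In this assay, trading trifluoromethyl, with 4 heavy atoms, for chloro, with 1, on this aromatic carbon gives a 1.1-fold lower number from compound 2 to compound 3 (0.06 log units; within the scatter) and so leaves the number within the scatter. Replacing the whole 3-nitrophenyl with 4-chlorophenyl gives a 1.4-fold higher number from compound 1 to compound 3 (0.15 log units; within the scatter) and also stays within the scatter, so compounds 1, 2 and 3 cannot be put in order. Nothing measured here offers an explanation for these results. Still open, going by these compounds, is whether an amine or a carboxylic acid at this position would shift the number beyond the scatter.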